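Longer bromoalkyl chain on a shared brominated core

This account rests on a few compounds, and the source may have more. Where it says the series, first, only, none or still open, it means among the compounds named here.

Measured compounds: compound 1 `C#CCOc1c(Br)cc(Br)cc1Oc1ccc(Br)cc1Br` gives 29.7 ug/mL in a functional assay on HL-60 cells (Homo sapiens) for cytotoxicity, read by MTT assay, with a stated time of 24 h; a lower number here means a stronger inhibitor, a higher number a weaker inhibitor; compound 3 `BrCCOc1c(Br)cc(Br)cc1Oc1ccc(Br)cc1Br` gives 26.2 ug/mL; compound 2 `Brc1ccc(Oc2cc(Br)cc(Br)c2OCCCCCN2CCN(c3ccccc3)CC2)c(Br)c1` gives 41.6 ug/mL.

Compound 1 holds the second highest of these three numbers; its nearest neighbour is compound 3, with a 1.1-fold lower number from compound 1 to compound 3 (0.05 log units; within the scatter), and compound 2 lies within the usual scatter of it as well. Compound 4 `BrCCCCOc1c(Br)cc(Br)cc1Oc1ccc(Br)cc1Br` differs from compound 1 by 3-bromopropyl in place of ethynyl on a saturated chain carbon bound to an oxygen on an aromatic ring. For the measured compounds named here, the only measured step that bears on this, a 1.1-fold lower number from compound 1 to compound 3 (0.05 log units; within the scatter), exchanged the same ethynyl for a bromomethyl on the same carbon and stayed within the scatter, so the longer 3-bromopropyl is expected to give no step beyond the scatter in this assay, namely a 1.1-fold lower number from compound 1 to compound 4 (0.04 log units; within the scatter). Compound 4 is therefore estimated at 27 ug/mL, within 14 ug/mL to 52 ug/mL.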

Compound 4, half-maximal inhibitory concentration: 25.9 ug/mL
Estimate against measurement, compound 4: 1.0-fold (0.02 log units) above, and the stated range covers the measured number.
By their numbers in this assay, from the lowest: compounds 4, 3, 1 and 2 (each within the scatter of the next).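

In this assay the 3-bromopropyl takes the place of the ethynyl with no step beyond the scatter, a 1.1-fold lower number from compound 1 to compound 4 (0.06 log units; within the scatter). Extending the chain by 2-bromoethyl in place of bromo likewise stays within the scatter, a 1.0-fold lower number from compound 3 to compound 4 (0.01 log units; within the scatter), so the side chains of compounds 1, 3 and 4 cannot be told apart at this position. Nothing available explains this. Still open, going by these compounds, is whether a carboxylic acid or an amine at the chain end, in place of the bromine, would give a step beyond the scatter. On these data alone, whether a still longer bromoalkyl chain would do so is also open.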